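Swapping dimethylamino for hydrogen on a carbonyl carbon

The source may report more compounds than this note shows. Statements on the series, on what has been measured and on what is new or still open speak of the compounds shown alone.

Values in a toxicity assay on CCRF-CEM cells (Homo sapiens) for cytotoxicity; a higher number here means that more compound is tolerated, a lower number that less compound is tolerated:
- Compound 1 `COC(=O)c1cccc2c1nc(-c1c(F)cccc1F)n2Cc1c(F)cccc1F`: 57.7 uM
- Compound 2 `CN(C)C(=O)c1cccc2c1nc(-c1c(F)cccc1F)n2Cc1c(F)cccc1F`: 80.1 uM
- Compound 3 `O=Cc1cccc2c1nc(-c1c(F)cccc1F)n2Cc1c(F)cccc1F`: not yet measured

For the measured compounds named here, compound 2 stands level with compound 1, the only other measured compound: the gap is a 1.4-fold higher number from compound 1 to compound 2 (0.14 log units; within the scatter). Compound 3 changes the same carbonyl carbon, with hydrogen in place of dimethylamino on a carbonyl carbon. Going by the values given here, the earlier step, dimethylamino in place of methoxy, is the only measured guide, and it is a weak one, since hydrogen has not been tested at this carbon. Going by these compounds, no step beyond the scatter is therefore expected in this assay, and the direction stays open. The expected change is a 1.3-fold lower number from compound 2 to compound 3 (0.13 log units; within the scatter). For compound 3 the estimate is 60 uM, with an expected range of 20 uM to 130 uM.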

Compound 3, half-maximal toxic concentration: 0.82 uM
Beside the measured number, compound 3's estimate is 73-fold (1.86 log units) above it; measured number below the stated range.
By their numbers in this assay, from the lowest: compound 3; then compounds 1 and 2 (each within the scatter of the next).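

Hydrogen in place of dimethylamino gives a 98-fold lower number from compound 2 to compound 3 (1.99 log units; beyond the scatter) and hydrogen in place of methoxy gives a 70-fold lower number from compound 1 to compound 3 (1.85 log units; beyond the scatter) in this assay at this carbonyl carbon. Compound 1 and compound 2 stand level, so those two groups alone gave no sign that this carbon could matter so much. The formyl group of compound 3 shows that the group on this carbon can set the number by a wide margin. Going by these compounds, whether a carboxylic acid, a primary amide or a hydroxymethyl group here would stay with compound 1 and compound 2 or fall with compound 3 remains open. No measurement at hand explains the drop.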